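The source may report more compounds than this note shows. Statements on the series, on what has been measured and on what is new or still open speak of the compounds shown alone.

In a functional assay on DU-145 cells (Homo sapiens) for antiproliferative activity, read by sulforhodamine B assay, with a stated time of 48 h (on this read-out higher numbers stand for weaker inhibition of growth and lower numbers for stronger inhibition of growth), compound 1 `COc1ccc(Nc2nc(NC3CCCC3)c3ccccc3n2)cc1` gives 12400 nM. Compound 2 `COc1ccc(N(C)c2nc(NCCCO)c3ccccc3n2)cc1` gives 30200 nM. Compound 3 `N#Cc1ccc(Nc2nc(NC3CCCC3)c3ccccc3n2)cc1` gives only a limit, > 31300 nM, so it has no exact place on the scale.

Compound 4 `O=C(O)c1ccc(Nc2nc(NC3CCCC3)c3ccccc3n2)cc1` differs from compound 3 by one change, carboxy in place of cyano on an aromatic carbon, para to a large group: carboxy in place of cyano on an aromatic carbon. Going by the values given here, one measured step bears on this place: an at least 2.5-fold higher number from compound 1 to compound 3 (0.40 log units; beyond the scatter), which puts cyano in place of methoxy. On these data alone, that step is at least modest and beyond the scatter, but its full size is unknown. Among the compounds with values here, no measured compound carries carboxy, and the only measured change at this place went towards weaker inhibition of growth, so no recovery is assumed in this assay. The expected step is a step that the limit leaves unreadable from compound 3 to compound 4, which means none beyond the scatter, and another limit is quite likely. The estimate for compound 4 is 32000 nM, with an expected range from 15000 nM to 65000 nM.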

Compound 4, concentration for 50% growth inhibition: 27300 nM
Compound 4: the middle estimate sits 1.2-fold (0.07 log units) above what was measured; the measured number falls inside the stated range.
By their numbers in this assay, from the lowest: compound 1; then compounds 4 and 2 (each within the scatter of the next). At a limit, above all of these: compound 3.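

With carboxy in place of methoxy, this position now has a replacement of exact size in this assay: a 2.2-fold higher number from compound 1 to compound 4 (0.34 log units; beyond the scatter). Both replacements of methoxy seen on this aromatic carbon, para to a large group, cyano and carboxy, now go the same way, towards weaker inhibition of growth, although they differ in their atoms and carboxy adds a hydrogen-bond donor. No order between carboxy and cyano can be read from an at least 1.1-fold lower number from compound 3 to compound 4 (0.05 log units; that floor lies within the scatter), whose floor lies within the scatter and which starts from a limit, not a number: the limit of > 31300 nM in this assay, at which 1 of the 4 values shown sits.

On these data alone, whether any group at this position gives a lower number than methoxy stays open, for example an amine, a hydroxy group or a longer ether chain. Also open, as far as these compounds go, is whether a methyl ester or a primary amide in place of carboxy would give a number like that of compound 4.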